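Capping the ring amine of compound 3

This account rests on a few compounds, and the source may have more. Where it says the series, first, only, none or still open, it means among the compounds named here.

Within the data shown here, in a functional assay on SK-OV-3 cells (Homo sapiens) for cytotoxicity, read by MTT assay, with a stated time of 3 days (on this read-out higher numbers stand for weaker inhibition and lower numbers for stronger inhibition), three compounds with a shared core have numbers so far. Compound 1 `N#Cc1c(Cl)nc(SCc2nc3ccccc3[nH]2)nc1-c1ccccc1` gives 3.37 nM, compound 2 `N#Cc1c(NC(N)=S)nc(SCc2nc3ccccc3[nH]2)nc1-c1ccccc1` gives 7.81 nM, and compound 3 `N#Cc1c(-c2ccccc2)nc(SCc2nc3ccccc3[nH]2)nc1N1CCNCC1` gives 2.63 nM. Compound 3 thus sits within the scatter of compound 1 and beyond it from compound 2.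

Compound 4 `N#Cc1c(-c2ccccc2)nc(SCc2nc3ccccc3[nH]2)nc1N1CCN(S(=O)(=O)c2ccccc2[N+](=O)[O-])CC1` differs from compound 3 in one place: (2-nitrophenyl)sulfonyl in place of hydrogen on an amine nitrogen in a ring. In words, this is (2-nitrophenyl)sulfonyl in place of hydrogen on an amine nitrogen in a ring.

Among the measured compounds shown here, no measured step changes that nitrogen, so the evidence is indirect. The nearest steps are swaps on an aromatic carbon: a 1.3-fold lower number from compound 1 to compound 3 (0.11 log units; within the scatter), a 2.3-fold higher number from compound 1 to compound 2 (0.37 log units; beyond the scatter) and a 3.0-fold lower number from compound 2 to compound 3 (0.47 log units; beyond the scatter). All three are small to modest, yet the new group is much larger, so a modest rise is expected rather than a large one. The expected change is a 2.3-fold higher number from compound 3 to compound 4 (0.36 log units; beyond the scatter) in this assay. Compound 4 is estimated at 6 nM, with an expected range from 1.5 nM to 25 nM.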

Compound 4, half-maximal inhibitory concentration: 3.2 nM
For compound 4 the middle estimate is 1.9-fold (0.27 log units) above the measured one; low and high end bracket the measured number.
By their numbers in this assay, from the lowest: compounds 3, 4 and 1 (each within the scatter of the next); then compound 2.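

Among these compounds, this is the first step that changes the amine nitrogen in the ring, and in this assay it gives a 1.2-fold higher number from compound 3 to compound 4 (0.09 log units; within the scatter), so this nitrogen accepts a very large addition without a shift beyond the scatter. The entering (2-nitrophenyl)sulfonyl brings 12 heavy atoms and a six-membered aromatic ring in place of a single hydrogen atom, which shows that a hydrogen on this nitrogen is not required for a low number in this assay. Nothing measured here accounts for why the number holds.

As far as these compounds go, it remains open whether smaller caps on the same nitrogen, such as a methyl or an acetyl group, or a phenylsulfonyl without the nitro group, would read alike. Also open, from the compounds shown here alone, is whether a carboxylic acid or a longer chain ending in an amine would be accepted at this nitrogen.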